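This account rests on a few compounds, and the source may have more. Where it says the series, first, only, none or still open, it means among the compounds named here.

Two compounds share a core in which a saturated ring bearing an amine nitrogen carries a benzyl group, and they differ only in what sits on that benzene ring. Compound 1 `Cc1c(C)c2ccc(OCC3CCN(Cc4ccc(CCO)cc4)CC3)cc2oc1=O` gives 120 nM in an assay for inhibition of Amine oxidase [flavin-containing] B (Homo sapiens), read by fluorescence, using microsomes, with a stated time of 30 min; a lower number here means a stronger inhibitor, a higher number a weaker inhibitor. Compound 2 `Cc1c(C)c2ccc(OCC3CCN(Cc4cccc(OCCCO)c4)CC3)cc2oc1=O` gives 780 nM in this assay, the higher of the two numbers, and the step from compound 1 to compound 2 was a 6.5-fold higher number from compound 1 to compound 2 (0.81 log units; beyond the scatter). Compound 3 `Cc1c(C)c2ccc(OCC3CCN(Cc4cccc(CO[N+](=O)[O-])c4)CC3)cc2oc1=O` has not yet been measured; it differs from compound 2 by (nitrooxy)methyl in place of 3-hydroxypropoxy on an aromatic carbon. Among the measured compounds shown here, the only measured step that bears on this change is the one from compound 1 to compound 2: it shows that altering the substituent on this benzene ring can move the number beyond the scatter, but it involves a different pair of groups, so it gives direction only loosely. Because compound 1 with its hydroxyethyl group sits at 120 nM, a group without the hydroxypropoxy chain is expected to fall somewhere between the two measured numbers. The step from compound 2 to compound 3 is therefore estimated as a 2.0-fold lower number from compound 2 to compound 3 (0.29 log units; within the scatter). Compound 3 is expected to give about 400 nM, within a range from 120 nM to 1500 nM.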

Compound 3, half-maximal inhibitory concentration: 51 nM
Compound 3: middle estimate off by 7.8-fold (0.89 log units), on the high side; the whole stated range lies above it.
By their numbers in this assay, from the lowest: compound 3; then compound 1; then compound 2.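

In this assay, replacing 3-hydroxypropoxy with (nitrooxy)methyl on an aromatic carbon gives a 15-fold lower number from compound 2 to compound 3 (1.18 log units; beyond the scatter). The two groups have the same count of heavy atoms, so among these compounds, a large change in the number occurs with no change in that count, although the entering group has no hydrogen-bond donor and a different atom make-up. The result also takes the series past the earlier low point, with a 2.4-fold lower number from compound 1 to compound 3 (0.37 log units; beyond the scatter), showing that a change on this benzene ring can give a number lower than that of compound 1; nothing available here accounts for either step.

The compounds shown leave open whether the lower number belongs to the nitrooxy group itself or to the shorter link that joins it to the ring, since compound 2 and compound 3 differ in both. A hydroxymethyl group or a 3-(nitrooxy)propoxy chain on the same aromatic carbon would separate those two readings, and the 4-((nitrooxy)methyl)phenyl group would show how far the place on the ring matters.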